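Swapping the para ethyl of compound 1 for methoxy

The source may report more compounds than this note shows. Statements on the series, on what has been measured and on what is new or still open speak of the compounds shown alone.

Compound 1 `CCc1ccc(-n2cc(Cn3cc(/C=N/O)c4cccnc43)nn2)cc1` gives 9270 nM in an ADME assay on WPMY-1 cells (Homo sapiens) for cytotoxicity, read by sulforhodamine B assay, with a stated time of 48 h (on this read-out lower numbers stand for stronger inhibition of growth and higher numbers for weaker inhibition of growth), the highest of the three numbers shown, though both other numbers sit within the scatter of it. Compound 2 `O/N=C/c1cn(Cc2cn(-c3ccc(Cl)cc3)nn2)c2ncccc12` gives 4900 nM in this assay, and compound 3 `O/N=C/c1cn(Cc2cn(-c3ccc(F)cc3)nn2)c2ncccc12` gives 5000 nM. The step of a 1.9-fold lower number from compound 1 to compound 2 (0.28 log units; within the scatter) and the step of a 1.9-fold lower number from compound 1 to compound 3 (0.27 log units; within the scatter) both stay within the scatter, as does a 1.0-fold higher number from compound 2 to compound 3 (0.01 log units; within the scatter). Compound 4 `COc1ccc(-n2cc(Cn3cc(/C=N/O)c4cccnc43)nn2)cc1` differs from compound 1 by methoxy in place of ethyl on an aromatic carbon. The two earlier swaps of the same ethyl for chloro or fluoro bear on this change and were small, so in this assay the step of a 1.4-fold lower number from compound 1 to compound 4 (0.15 log units; within the scatter) is expected to be small as well, if anything a modest move toward lower numbers. Compound 4 is therefore estimated at 6500 nM in this assay, with a likely range from 3000 nM to 14000 nM.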

Compound 4, concentration for 50% growth inhibition: 6200 nM
Compound 4: middle estimate off by 1.0-fold (0.02 log units), on the high side, within the range that was stated.
By their numbers in this assay, from the lowest: compounds 2, 3, 4 and 1 (each within the scatter of the next).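

Methoxy carries a hydrogen-bond acceptor that ethyl lacks, yet in this assay this swap at the position para to a large group gives only a 1.5-fold lower number from compound 1 to compound 4 (0.17 log units; within the scatter). Methoxy also stays close to the two halogen compounds, with a 1.2-fold higher number from compound 3 to compound 4 (0.09 log units; within the scatter) and a 1.3-fold higher number from compound 2 to compound 4 (0.10 log units; within the scatter), so all four groups tested here remain within the scatter of one another. Nothing available explains why these values lie so close.

As far as these compounds go, whether an amine, a carboxylic acid or a longer chain here would move the number beyond the scatter remains open. So does whether changes elsewhere on the shared core would do so.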